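Fluoro added to the shared core of compound 3

The compounds below may be only part of what the source reports. "The series", "measured", "known", "first", "only" and "open" are said of these compounds alone.

Values in an ADME assay on HUVEC cells (Homo sapiens) for inhibition, read by CCK-8 assay, with a stated time of 24 h, in the presence of a further agent that is not named here (a lower number here means a stronger inhibitor, a higher number a weaker inhibitor), follow.
- compound 1 `Cc1ccccc1-n1cc(-c2ccc(/C=C3\C(=O)Nc4ccccc43)cc2)nn1` gives 14700 nM
- compound 2 `O=C1Nc2ccccc2/C1=C/c1ccc(-c2cn(-c3ccc(F)cc3)nn2)cc1` gives 14700 nM
- compound 3 `O=C1Nc2ccccc2/C1=C/c1ccc(-c2cn(-c3cccc(Cl)c3)nn2)cc1` gives > 20000 nM (a limit, not a number)

Compound 3 stands at a limit of the assay, with no number measured for it. The next compound, compound 4 `O=C1Nc2ccc(F)cc2/C1=C/c1ccc(-c2cn(-c3cccc(Cl)c3)nn2)cc1`, carries fluoro in place of hydrogen on an aromatic carbon. This carbon belongs to a six-membered aromatic ring of carbon only, part of a fused system of two rings.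

All three measured steps change the group on an aromatic nitrogen, so they bear on this change only indirectly. Among the compounds with values here, the first is no change at the digits printed from compound 1 to compound 2 (within the scatter). The other two are an at least 1.3-fold higher number from compound 1 to compound 3 (0.13 log units; that floor lies within the scatter) and an at least 1.3-fold higher number from compound 2 to compound 3 (0.13 log units; that floor lies within the scatter). Within the data shown here, none of them shows a change beyond the scatter, and no measured step touches the fused system. No step beyond the scatter is therefore expected in this assay, and compound 4 may also end up reported only as a limit. The expected step is a number no higher from compound 3 to compound 4 (the limit leaves the size open). Compound 4 is estimated at 20000 nM, with an expected range from 9000 nM to 40000 nM.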

Compound 4, half-maximal inhibitory concentration: 19400 nM
Compound 4: the middle estimate sits 1.0-fold (0.01 log units) above what was measured, and the stated range covers the measured number.
By their numbers in this assay, from the lowest: compounds 1, 2 and 4 (each within the scatter of the next). At a limit, above all of these: compound 3.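

This is the first change shown on the fused system rather than on the group on the aromatic nitrogen: in this assay fluoro in place of hydrogen on an aromatic carbon gives an at least 1.0-fold lower number from compound 3 to compound 4 (0.01 log units; that floor lies within the scatter) and leaves compound 4 with a measured value of 19400 nM. For compound 3 the entry is > 20000 nM, which is a limit and not a number. The true size of this step cannot be read, and the result shows only that fluoro at this carbon gives a readable value with 3-chlorophenyl on the aromatic nitrogen, because the comparison starts from a limit: the limit of > 20000 nM in this assay, at which 1 of the 4 values shown sits.

Still open, from the compounds shown here alone, is how other groups on this carbon, such as an amine, a methoxy group or a carboxylic acid, would read in this assay. Also open, going by these compounds, is whether fluoro at this carbon gives a step of any size when the aromatic nitrogen carries 2-methylphenyl or 4-fluorophenyl, where the starting compounds have numbers rather than a limit.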